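This account rests on a few compounds, and the source may have more. Where it says the series, first, only, none or still open, it means among the compounds named here.

The measured compounds, in a functional assay on cells (leukaemia cell line, Homo sapiens) for inhibition, read by sulforhodamine B assay, with a stated time of 48 h; on this read-out lower numbers stand for higher toxicity in this test and higher numbers for lower toxicity in this test:

Compound 1, `O=S(=O)(Nc1ccc(Br)c(Cl)c1)c1ccc(-c2cnc(C3CC3)o2)cc1`, comes back only as a limit of the assay: compound 1 gives > 100000 nM.
Compound 2, `Cc1ccc(NS(=O)(=O)c2ccc(-c3cnc(C4CC4)o3)cc2)cc1C`, is likewise a limit: compound 2 gives > 100000 nM.
Compound 3, `O=S(=O)(Nc1ccc(F)cc1F)c1ccc(-c2cnc(C3CC3)o2)cc1`, is also a limit: compound 3 gives > 100000 nM.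

Compound 1 therefore stands at the assay's limit, as do the two others, a point summed up by the line that (the limit of > 100000 nM in this assay, at which 3 of the 3 values shown sit). The steps among these three, a step that the two limits leave unreadable from compound 1 to compound 2, a step that the two limits leave unreadable from compound 1 to compound 3 and a step that the two limits leave unreadable from compound 2 to compound 3, cannot be read, since both ends of each sit at the limit. Compound 4, `O=S(=O)(Nc1ccc(I)c(Cl)c1)c1ccc(-c2cnc(C3CC3)o2)cc1`, differs from compound 1 by iodo in place of bromo on an aromatic carbon. Among the compounds with values here, none of the measured steps changes the group at this position, so no step bears directly on it; what the three show is only that varied groups on the sulfonamide nitrogen all remain at the limit. Compound 4 is therefore expected to stay at the limit too, a step that the limit leaves unreadable from compound 1 to compound 4 in this assay . The estimated value of compound 4 is 150000 nM, between 50000 nM and 500000 nM.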

Compound 4, concentration lethal to 50% of the cells: > 100000 nM
Compound 4 was reported as a limit; the forecaster's own chance of this, stated with the estimate: 85%; the middle value does not contradict the limit.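

Compound 4 also comes back only as a limit in this assay, so its steps to compound 1, compound 2 and compound 3 cannot be read: the limit of > 100000 nM in this assay, at which 4 of the 4 values shown sit. The compounds shown leave open whether any change to these groups would give a measurable value.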